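Amide nitrogen substituent change on the shared core

A few compounds are considered here, and "the series" means these few. Any claim that something is new, unique, unknown or untested is made for them only; others in the source may bear on it.

Compound 1 `C=CC1=C(C(=O)NCc2ccccc2)C(c2ccc(OC)cc2)OC1` carries a benzyl group on the amide-type nitrogen. In a functional assay on A549 cells (Homo sapiens) for cytotoxicity, read by MTT assay, with a stated time of 24 h (on this read-out lower numbers stand for stronger inhibition and higher numbers for weaker inhibition), compound 1 gives > 100000 nM, which is a limit of the assay and not a number. Compound 2 `C=CC1=C(C(=O)NC(C)(C)C)C(c2ccc(OC)cc2)OC1` carries tert-butyl instead. In this assay compound 2 gives > 100000 nM, again a limit rather than a number. The step that the two limits leave unreadable from compound 1 to compound 2 therefore cannot be sized, since both values sit at the limit of > 100000 nM in this assay, at which 2 of the 2 values shown sit. Compound 2 thus stands only at a limit, without a measured potency. Compound 3 `C=CC1=C(C(=O)Nc2ccc(OCC)cc2)C(c2ccc(OC)cc2)OC1` is not yet measured; it differs from compound 2 by 4-ethoxyphenyl in place of tert-butyl on an amide-type nitrogen. Among the measured compounds shown here, the one measured step concerns the same nitrogen but is unreadable, so no direction can be taken from it. Compound 3 is expected to give 120000 nM, in the range 40000 nM to 400000 nM. The expected step that the limit leaves unreadable from compound 2 to compound 3 is essentially none beyond the scatter, with a limit the most likely outcome.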

Compound 3, half-maximal inhibitory concentration: 17600 nM
Compound 3: the middle estimate sits 6.8-fold (0.83 log units) above what was measured, outside the stated range (below it).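

In this assay, the change to 4-ethoxyphenyl gives an at least 5.6-fold lower number from compound 2 to compound 3 (0.75 log units; beyond the scatter), and the change from benzyl to the same group gives an at least 5.6-fold lower number from compound 1 to compound 3 (0.75 log units; beyond the scatter). The read-out therefore responds to the substituent on the amide-type nitrogen, which the unreadable comparison of the two earlier compounds could not show. The aromatic ring alone does not account for this, since benzyl also holds one, and both steps give only minimum sizes, as the two earlier compounds stand at a limit and not at a number: the limit of > 100000 nM in this assay, at which 2 of the 3 values shown sit.

The compounds shown leave open whether the ethoxy group itself contributes to the step or whether the phenyl ring on that nitrogen is sufficient. A plain phenyl, or a phenyl carrying an amine or a carboxylic acid in place of ethoxy, would separate these two readings.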